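Removing the pyrimidin-2-yl group from compound 2

A few compounds are considered here, and "the series" means these few. Any claim that something is new, unique, unknown or untested is made for them only; others in the source may bear on it.

Of the compounds shown here, two on the shared core have been measured so far. In a functional assay on MCF7 cells (Homo sapiens) for antiproliferative activity, read by sulforhodamine B assay, with a stated time of 72 h (on this read-out higher numbers stand for weaker inhibition and lower numbers for stronger inhibition), compound 1 (`CCN1C(=O)CS/C1=N/Nc1nncc2ccccc12`) gives 98 nM and compound 2 (`O=S(=O)(Nc1ncccn1)c1ccc(Nc2nncc3ccccc23)cc1`) gives 64 nM as its half-maximal inhibitory concentration. Compound 2 therefore stands level with compound 1, as the two numbers lie within the scatter of each other.

Compound 3 (`NS(=O)(=O)c1ccc(Nc2nncc3ccccc23)cc1`) has not yet been measured. It differs from compound 2 by hydrogen in place of pyrimidin-2-yl on a sulfonamide nitrogen. Within the data shown here, no measured pair shows this change, so the expectation has little direct support. Among the measured compounds shown here, the only guide is that compound 1 and compound 2 carry quite different groups on the shared core, yet their values do not separate. A large step is therefore not expected in this assay for this change. The estimated step of a 1.9-fold higher number from compound 2 to compound 3 (0.27 log units; within the scatter) is small, expected towards a higher number and thus weaker inhibition, and stays about the size of the usual scatter. For compound 3 the expected value is 120 nM (estimated range 35 nM to 400 nM) in this read-out.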

Compound 3, half-maximal inhibitory concentration: 37 nM
Estimate against measurement, compound 3: 3.2-fold (0.51 log units) above; the measured number falls inside the stated range.
By their numbers in this assay, from the lowest: compounds 3, 2 and 1 (each within the scatter of the next, the first and the last beyond it).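

In this assay, among these compounds, this is the first direct reading of a change on the sulfonamide nitrogen: a 1.7-fold lower number from compound 2 to compound 3 (0.24 log units; within the scatter), so compound 3 stands level with compound 2. On this pair, losing the pyrimidin-2-yl group, with its 6 heavy atoms and one six-membered aromatic ring, leaves the value within the scatter, and hydrogen on this nitrogen is enough to keep inhibition in the same range on the shared core. The data at hand offer no measurement that could explain this tolerance, so the result stands as an observation on a single pair.

Since only hydrogen and pyrimidin-2-yl are shown on the sulfonamide nitrogen, it remains open whether groups of other kinds, such as a methyl, an acetyl or a phenyl group, would also stay level with compound 3. Also open, as far as these compounds go, is how much the sulfonamide itself contributes, which a carboxylic acid or a primary amide at the same place on the shared core would help to show.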